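A few compounds are considered here, and "the series" means these few. Any claim that something is new, unique, unknown or untested is made for them only; others in the source may bear on it.

Compound 2 `Cc1cnc(Nc2ccc(C(=O)Nc3c(C)cccc3C)cc2)nc1-c1ccc(C#N)cc1` has the lowest number of the two measured here: in an assay on NIH3T3 cells for inhibition of Sonic hedgehog protein (Mus musculus), read by a luciferase reporter, with a stated time of 48 h (on this read-out lower numbers stand for stronger inhibition and higher numbers for weaker inhibition), compound 2 gives 2.8 nM, while compound 1 `Cc1ccccc1C(=O)Nc1ccc(Nc2ncc(C)c(-c3ccc(OC(F)(F)F)cc3)n2)cc1` gives 42.1 nM, a gap beyond the scatter. Compound 3 `Cc1cnc(Nc2ccc(C(=O)Nc3c(C)cccc3C)cc2)nc1Cc1ccccc1` is not yet measured; it differs from compound 2 in one place: benzyl in place of 4-cyanophenyl on an aromatic carbon. Among the compounds with values here, no measured step of this kind exists to lean on, so the change is expected to weaken inhibition and raise the number beyond the scatter, with the expected step being an 18-fold higher number from compound 2 to compound 3 (1.25 log units; beyond the scatter). Compound 3 is estimated at 50 nM, within a range of 10 nM to 300 nM.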

Compound 3, half-maximal inhibitory concentration: 34.3 nM
For compound 3 the middle estimate is 1.5-fold (0.16 log units) above the measured one; low and high end bracket the measured number.
By their numbers in this assay, from the lowest: compound 2; then compounds 3 and 1 (each within the scatter of the next).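

In this assay, placing benzyl instead of 4-cyanophenyl on this aromatic carbon gives a 12-fold higher number from compound 2 to compound 3 (1.09 log units; beyond the scatter), so what this position carries clearly matters. Inhibition is weakened by this change, but compound 3 remains measurable on this read-out. Nothing measured here explains the size of this step.

The change removes the nitrile and adds the benzyl carbon link together, so their separate contributions cannot be told apart. On these data alone, how a plain phenyl or a morpholine would compare at this position remains open.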